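Bromo on the phenyl of a weak cell-growth inhibitor

A few compounds are considered here, and "the series" means these few. Any claim that something is new, unique, unknown or untested is made for them only; others in the source may bear on it.

Within the data shown here, compound 1, with the structure `CC(c1ccc(-c2ccccc2)c(F)c1)c1nnc2n1N=C(c1ccccc1)CS2`, is one of two compounds with a number so far. In a functional assay on MCF7 cells (Homo sapiens) for inhibition, read by sulforhodamine B assay, with a stated time of 72 h (a higher number here means a weaker inhibitor, a lower number a stronger inhibitor), compound 1 gives 7400 nM, the lower of the two numbers. The other measured compound is compound 2, with the structure `CC(C)Cc1ccc(C(C)c2nnc3n2N=C(c2ccc(Cl)cc2)CS3)cc1`; in this assay compound 2 gives 8800 nM. The two values sit within the scatter of each other, so nothing can be said about which of the two inhibits more strongly, and no single change connects their structures.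

Compound 3, with the structure `CC(c1ccc(-c2ccccc2)c(F)c1)c1nnc2n1N=C(c1ccc(Br)cc1)CS2`, has not yet been measured. It differs from compound 1 in one place: bromo in place of hydrogen on an aromatic carbon. The difference, seen one bond further out, reads phenyl to 4-bromophenyl.

Among the measured compounds shown here, no measured pair shows what such a change does here. Compound 2 carries a chloro on the corresponding ring, yet it also differs elsewhere, so it gives no clean guide. The expected step in this assay is therefore small, within the scatter, with no clear direction; for compound 3 this means an estimated step of a 1.2-fold lower number from compound 1 to compound 3 (0.09 log units; within the scatter). Compound 3 is expected to give about 6000 nM, with a range from 2500 nM to 15000 nM.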

Compound 3, half-maximal inhibitory concentration: 7400 nM
Beside the measured number, compound 3's estimate is 1.2-fold (0.09 log units) below it, within the range that was stated.
By their numbers in this assay, from the lowest: compounds 1, 3 and 2 (each within the scatter of the next).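

In this assay, among these compounds, putting bromo on this phenyl gives no change at the digits printed from compound 1 to compound 3 (within the scatter), the first direct reading of a single change at this ring, which the two earlier compounds could not provide because they differ in more than one place. The carbon para to a large group therefore accepts one bromine atom in place of hydrogen without a shift beyond the usual scatter, in either direction, so this change neither improves nor costs inhibition of cell growth in this measurement. No measurement at hand accounts for how small this step is.

Going by these compounds, what remains open is whether this position stays as unresponsive with a group of a different kind, such as an amine, a carboxylic acid or a longer chain like a butyl group, any of which would test it far more sharply than one halogen atom can. It is also unclear whether the same bromo would give a similarly small step on a compound that differs elsewhere in its structure, since a single pair says nothing about other parts of the molecule.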